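From Dimethylamino to Methyl at the Assay Ceiling

A few compounds are considered here, and "the series" means these few. Any claim that something is new, unique, unknown or untested is made for them only; others in the source may bear on it.

This account concerns growth inhibition in a functional assay on HepG2 cells (Homo sapiens) for cytotoxicity, read by sulforhodamine B assay, with a stated time of 72 h; on this read-out higher numbers stand for weaker inhibition and lower numbers for stronger inhibition. Of the compounds shown here, three of a shared core have been measured. Compound 1 `Cc1c(-c2csc(NC(=S)Nc3ccccc3)n2)c(=O)n(-c2ccccc2)n1C`, a thiourea on that core, gives 8350 nM in this assay. Compound 2 `Cc1c(-c2csc(/N=C3\S/C(=C\c4ccc(Cl)cc4)C(=O)N3c3ccccc3)n2)c(=O)n(-c2ccccc2)n1C` carries a chlorophenyl on a cyclised ring; in this assay compound 2 reaches only the limit > 100000 nM, which is a limit of the assay and not a number. Compound 3 `Cc1c(-c2csc(/N=C3\S/C(=C\c4ccc(N(C)C)cc4)C(=O)N3c3ccccc3)n2)c(=O)n(-c2ccccc2)n1C` carries a dimethylaminophenyl in the same position; in this assay compound 3 likewise stops at the limit > 100000 nM. The step that the two limits leave unreadable from compound 2 to compound 3 therefore cannot be read in size or direction. Compound 3 thus stands at the ceiling of the numbers shown, alongside compound 2, with only compound 1 giving a finite value.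

Compound 4 `Cc1ccc(/C=C2\S/C(=N\c3nc(-c4c(C)n(C)n(-c5ccccc5)c4=O)cs3)N(c3ccccc3)C2=O)cc1` differs from compound 3 by methyl in place of dimethylamino on an aromatic carbon. Within the data shown here, the only measured step on this phenyl ring is the unreadable one from compound 2 to compound 3, and both partners sit at the limit of > 100000 nM in this assay, at which 2 of the 3 values shown sit. Among the measured compounds shown here, no step shows a substituent on this ring moving a compound away from that ceiling. The step of a number no higher from compound 3 to compound 4 (the limit leaves the size open) is therefore expected to remain unreadable, with no movement beyond the scatter. Compound 4 is expected at 100000 nM, within 40000 nM to 300000 nM, most likely again reported as a limit.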

Compound 4, half-maximal inhibitory concentration: > 100000 nM
Compound 4: no number, only a limit; the forecaster's own chance of this, stated with the estimate: 85%; the middle value sits exactly at the limit.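

In this assay compound 4 gives > 100000 nM, which is a limit of the assay and not a number. The steps among compound 2, compound 3 and compound 4 cannot be read in size or direction. The compounds shown leave open what any substituent on this phenyl ring does to growth inhibition, with most values stopping at one ceiling: the limit of > 100000 nM in this assay, at which 3 of the 4 values shown sit.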